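Notes on compound 1 and a 4-fluorobenzyl analogue

The source may report more compounds than this note shows. Statements on the series, on what has been measured and on what is new or still open speak of the compounds shown alone.

Compound 1 `Nc1cc(N)c2nc(-c3ccccc3)c(NCc3ccc(Cl)c(Cl)c3)nc2c1` was run in a functional assay on NCI/ADR-RES cells (Homo sapiens) for inhibition, read by sulforhodamine B assay, with a stated time of 48 h; a higher number here means that more compound is tolerated, a lower number that less compound is tolerated. In this assay compound 1 returns only a limit, < 100000 nM. Compound 2 `Nc1cc(N)c2nc(-c3ccccc3)c(Sc3ccc(Cl)c(Cl)c3)nc2c1` likewise returns a limit in this assay, < 100000 nM. Compound 3 `CCOC(=O)[C@H](CCC(=O)O)NC(=O)c1ccc(Oc2nc3cc(N)cc(N)c3nc2-c2ccccc2)cc1` also returns a limit in this assay, < 100000 nM. Every value shown is thus (the limit of < 100000 nM in this assay, at which 3 of the 3 values shown sit), so compound 1 cannot be placed above or below either companion; it stands level with them at the limit. Among the compounds with values here, no step between measured compounds is available. Compound 4 `Nc1cc(N)c2nc(-c3ccccc3)c(NCc3ccc(F)cc3)nc2c1` differs from compound 1 by 4-fluorophenyl in place of 3,4-dichlorophenyl on a saturated chain carbon bound to a nitrogen on an aromatic ring. Within the data shown here, with three limits and no measured step, the estimated step that the limit leaves unreadable from compound 1 to compound 4 is taken as none beyond the scatter. Compound 4 is therefore expected to give about 50000 nM, within 10000 nM to 100000 nM, most likely reported again as a limit.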

Compound 4, concentration lethal to 50% of the cells: 28200 nM
Compound 4: middle estimate off by 1.8-fold (0.25 log units), on the high side; the range from low to high includes it.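

The steps from compound 1 and compound 2 to compound 4 cannot be read, because the values of compound 1 and compound 2 are limits: the limit of < 100000 nM in this assay, at which 3 of the 4 values shown sit.

From the compounds shown here alone, whether 4-fluorobenzyl and 3,4-dichlorobenzyl differ in this read-out stays open.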